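The compounds below may be only part of what the source reports. "The series", "measured", "known", "first", "only" and "open" are said of these compounds alone.

Among the compounds with values here, in a functional assay for inhibition, with Rattus norvegicus as the target (on this read-out lower numbers stand for stronger inhibition and higher numbers for weaker inhibition), compound 3 `CCC(CC)/N=c1\c(O)c(O)\c1=N/c1ccc(C#N)cc1` gives 3340 nM and lies within the scatter of compound 2 `C[C@@H](/N=c1\c(O)c(O)\c1=N/c1ccc2c[nH]nc2c1)C(C)(C)C` with 4600 nM as the only other number. Compound 1 `Nc1c(Nc2cccnc2)c(=O)c1=O` gives > 30000 nM which is a limit and not a number. Compound 4 `C/N=c1\c(O)c(O)\c1=N/c1ccc(C#N)cc1` follows from compound 3 through methyl in place of pentan-3-yl on a double-bonded nitrogen with methyl in place of pentan-3-yl on a double-bonded nitrogen. Within the data shown here, no measured pair covers this change, so the expectation in this assay is tentative: a moderate step toward a higher number and beyond the scatter. The estimated change is a 3.0-fold higher number from compound 3 to compound 4 (0.48 log units; beyond the scatter) in size. For compound 4 the expected value is 10000 nM with an estimated range from 3000 nM to 30000 nM on this read-out.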

Compound 4, half-maximal inhibitory concentration: > 30000 nM
Compound 4 ended at the assay's limit; the forecaster's own chance of this, stated with the estimate: 20%; middle value at least 3.0-fold (0.47 log units) from the limit.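

Within the data shown here, on the double-bonded nitrogen, replacing pentan-3-yl with methyl gives the first direct step, and it is beyond the scatter in this assay (an at least 8.9-fold higher number from compound 3 to compound 4 (0.95 log units; beyond the scatter)). Compound 4 gives > 30000 nM which is a limit and not a number. The step therefore has a lower bound only, because compound 4 sits at the limit of the assay: the limit of > 30000 nM in this assay, at which 2 of the 4 values shown sit.

As far as these compounds go, whether ethyl or isopropyl on this nitrogen stays near compound 3 remains open. A ring such as cyclohexyl in this place is also untested in the compounds shown.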